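Phenoxy ethers: expected cytotoxicity of the unsubstituted phenyl analogue

The compounds below may be only part of what the source reports. "The series", "measured", "known", "first", "only" and "open" are said of these compounds alone.

Compound 3 `Cc1cc(Br)cc(Br)c1Oc1nc(Nc2ccc(C#N)cc2)nc2ccccc12` gives 150000 nM in an ADME assay on MT4 cells (Homo sapiens) for cytotoxicity, read by MTT assay, with a stated time of 4 days (on this read-out higher numbers stand for lower toxicity in this test and lower numbers for higher toxicity in this test), and stands second highest of the three numbers measured. Compound 1 `Cc1cccc(Oc2nc(Nc3ccc(C#N)cc3)nc3ccccc23)c1` gives 355000 nM in this assay, and compound 2 `N#Cc1ccc(Nc2nc(Oc3ccc(Cl)cc3Cl)c3ccccc3n2)cc1` gives 32000 nM. The change to compound 4 `N#Cc1ccc(Nc2nc(Oc3ccccc3)c3ccccc3n2)cc1` is phenyl in place of 2,4-dibromo-6-methylphenyl on an oxygen on an aromatic ring. For the measured compounds named here, the steps that bear on it are a 2.4-fold lower number from compound 1 to compound 3 (0.37 log units; beyond the scatter) and a 4.7-fold higher number from compound 2 to compound 3 (0.67 log units; beyond the scatter), both modest, whereas an 11-fold lower number from compound 1 to compound 2 (1.05 log units; beyond the scatter) was large. Compound 1, the only halogen-free ether measured, carries the highest number, so a modest rise is expected for compound 4, a 2.0-fold higher number from compound 3 to compound 4 (0.30 log units; within the scatter). The estimate for compound 4 in this assay is 300000 nM, with a range from 120000 nM to 700000 nM.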

Compound 4, half-maximal cytotoxic concentration: 370000 nM
Estimate against measurement, compound 4: 1.2-fold (0.09 log units) below; the measured number falls inside the stated range.
By their numbers in this assay, from the lowest: compound 2; then compound 3; then compounds 1 and 4 (each within the scatter of the next).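

In this assay, phenyl in place of the halogenated rings gives both a 2.5-fold higher number from compound 3 to compound 4 (0.39 log units; beyond the scatter) and a 12-fold higher number from compound 2 to compound 4 (1.06 log units; beyond the scatter), so on this oxygen both halogen-bearing ethers carry lower numbers than the unsubstituted phenyl. Hydrogen in place of methyl on an aromatic carbon gives a 1.0-fold higher number from compound 1 to compound 4 (0.02 log units; within the scatter), which places compound 4 within the scatter of compound 1. The methyl of compound 1 therefore shows no separable effect on this read-out.

No evidence on the origin of these steps is at hand. From the compounds shown here alone, whether a single chlorine or a methoxy group on the phenyl would give a number nearer compound 2 or compound 4 stays open.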